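Series notes: ring amine in place of open-chain amine

The source may hold more compounds than are shown below. What is called first, only, known or untested is meant among the compounds shown, and "the series" means these compounds.

Within the data shown here, compound 2 `Cc1ccc(NC(=O)Nc2ccc(Oc3cc(N(C)CCN(C)C)ncn3)cc2)cc1C(F)(F)F` stands highest of the two numbers measured so far: in a functional assay on BaF3 cells (Mus musculus) for inhibition, read by CCK-8 assay, with a stated time of 72 h (on this read-out higher numbers stand for weaker inhibition of growth and lower numbers for stronger inhibition of growth), compound 2 gives 9410 nM, whereas compound 1 `CC(=O)Nc1cc(Oc2ccc(NC(=O)Nc3ccc(CN4CCN(C)CC4)c(C(F)(F)F)c3)cc2)ncn1` gives 50 nM, a far lower number, beyond the scatter. Compound 3 `Cc1ccc(NC(=O)Nc2ccc(Oc3cc(N4CCN[C@H](C)C4)ncn3)cc2)cc1C(F)(F)F` differs from compound 2 by 3-methylpiperazin-1-yl in place of (2-(dimethylamino)ethyl)(methyl)amino on an aromatic carbon. Among the measured compounds shown here, no measured pair carries this change, so its size is unknown; the open-chain amine of compound 2 gives the weakest value seen, and the change may bring a modest gain or none beyond the scatter. Compound 3 is expected to give 3000 nM, within a range of 600 nM to 15000 nM. The estimated step is a 3.1-fold lower number from compound 2 to compound 3 (0.50 log units; beyond the scatter).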

Compound 3, concentration for 50% growth inhibition: 8920 nM
Beside the measured number, compound 3's estimate is 3.0-fold (0.47 log units) below it, and the stated range covers the measured number.
By their numbers in this assay, from the lowest: compound 1; then compounds 3 and 2 (each within the scatter of the next).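

In this assay, 3-methylpiperazin-1-yl in place of (2-(dimethylamino)ethyl)(methyl)amino gives a 1.1-fold lower number from compound 2 to compound 3 (0.02 log units; within the scatter) on this aromatic carbon. At this position, then, exchanging the open chain for this ring, with its added hydrogen-bond donor and defined stereocentre, brings no change beyond the scatter. No available evidence bears on this result.

Open, on these data alone, is whether a morpholin-4-yl or an acetamido group on this carbon, with the rest of compound 2 kept, would shift the number. Compound 1 differs from compound 2 and compound 3 in more than one place, so its gap to them cannot be assigned to any single group.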